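From methylamino to isopropylamino in a clearance test

This account rests on a few compounds, and the source may have more. Where it says the series, first, only, none or still open, it means among the compounds named here.

Compound 1 `CC#Cc1cc(C(O)(C(F)(F)F)C(F)(F)F)cnc1-c1ccc(S(=O)(=O)c2ccc(N)nc2)cc1` gives 177 mL.min-1.g-1
Compound 2 `CNc1nc(S(=O)(=O)c2ccc(N)nc2)ccc1-c1ccc(C(C)(O)C(F)(F)F)cn1` gives 21 mL.min-1.g-1

Both numbers come from an ADME assay (liver) for metabolic stability, with Liver microsome (Rattus norvegicus) as the target, using microsomes and NADPH, with a stated time of 30 min, at 37 degrees C, tested at 1 uM (a lower number here means slower removal, a higher number faster removal of the compound), and show how quickly each compound is removed. Compound 2 is the lower of the two at 21 mL.min-1.g-1 and compound 1 gives 177 mL.min-1.g-1, a gap beyond the usual scatter. These two structures differ in more than one place, so their gap cannot be tied to any single change.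

Compound 3 `CC(C)Nc1nc(S(=O)(=O)c2ccc(N)nc2)ccc1-c1ccc(C(C)(O)C(F)(F)F)cn1` is still unmeasured and departs from compound 2 in one place only. The change is isopropyl in place of methyl on a nitrogen on an aromatic ring and reads in words as isopropyl in place of methyl on a nitrogen on an aromatic ring.

Going by the values given here, no measured pair isolates this change, so the expectation stays cautious and is anchored on compound 2 at 21 mL.min-1.g-1 as its starting point. The expected 1.7-fold higher number from compound 2 to compound 3 (0.22 log units; within the scatter) is a small rise in this assay that may not clear the usual scatter. For compound 3 the estimate is 35 mL.min-1.g-1 (expected range 15 mL.min-1.g-1 to 85 mL.min-1.g-1).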

Compound 3, intrinsic clearance in microsomes: 62 mL.min-1.g-1
The estimate for compound 3 lay 1.8-fold (0.25 log units) below the measured number; the measured number falls inside the stated range.
By their numbers in this assay, from the lowest: compound 2; then compound 3; then compound 1.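

Going by these compounds alone, compound 2 and compound 3 form the first pair here that differ in one place only, so the change of methyl to isopropyl on a nitrogen on an aromatic ring can be read on its own. In this assay, this change gives a 3.0-fold higher number from compound 2 to compound 3 (0.47 log units; beyond the scatter), which shows that the group carried on this nitrogen is not a silent detail for the speed of removal from rat liver microsomes, even though everything else in the two structures stays the same. Nothing available here explains the rise in clearance, so the step stands as an observation without a known cause.

A single pair gives a direction but not a trend, and an ethylamino or cyclopropylamino group at this nitrogen, or a plain amino group there, would show whether the number climbs gradually with a larger chain or depends on the isopropyl group itself. Going by these compounds, it also remains open whether the same change would have a similar effect on a different core, such as the core of compound 1.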